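The source may hold more compounds than are shown below. What is called first, only, known or untested is meant among the compounds shown, and "the series" means these compounds.

Measured so far:
- compound 1, `COc1ccccc1C(=O)NCc1ccc(CNS(=O)(=O)c2ccc([N+](=O)[O-])cc2)cc1`: 100 nM
- compound 2, `Cc1cccc(S(=O)(=O)NCc2ccc(CNC(=O)c3ccccc3C)cc2)c1`: 1000 nM
- compound 3, `O=C(NCc1ccc(CNS(=O)(=O)c2ccc(Cl)cc2)cc1)c1cccnc1`: 1000 nM

All three were read in an assay on MDA-MB-231 cells for displacement of a labelled ligand from C-X-C chemokine receptor type 4 (Homo sapiens), read by fluorescence and microscopy, with stated times of 10 min and 30 min; on this read-out higher numbers stand for an effect only at larger amounts of compound and lower numbers for an effect already at smaller amounts. Compound 2 sits level with compound 3 at the digits shown, the two together giving the highest numbers of the set, while compound 1 stands a full order below; only that gap to compound 1 lies beyond the scatter. Among the measured compounds shown here, no step between two measured compounds differs in a single place, so the run to compound 4, `Cc1ccccc1C(=O)NCc1ccc(CNS(=O)(=O)c2ccccc2F)cc1`, rests on the structural change alone: 2-fluorophenyl in place of 3-methylphenyl on a sulfonyl sulfur. With nothing comparable measured, the expected step of no change at the digits printed from compound 2 to compound 4 (within the scatter) is set to none beyond the scatter. Compound 4 is therefore estimated at 1000 nM, with a range from 300 nM to 3000 nM.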

Compound 4, effective concentration (reported as EC, without a stated level of effect): 1000 nM
Estimate against measurement, compound 4: no gap at the digits printed; the range from low to high includes it.
By their numbers in this assay, from the lowest: compound 1; then compounds 2, 3 and 4 (each within the scatter of the next).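

In this assay, among the compounds shown here, 2-fluorophenyl in place of 3-methylphenyl on a sulfonyl sulfur gives no change at the digits printed from compound 2 to compound 4 (within the scatter), the first single-place reading. This position therefore accepts this exchange of one aryl group for another with the rest of compound 2 held fixed, at least for this pair. No supporting data on the two groups accompany this reading.

From the compounds shown here alone, the effect of an amine or a carboxylic acid at this sulfonyl sulfur remains open. So does which part of compound 1 goes with its 100 nM, as no single-place step reaches it.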